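A few compounds are considered here, and "the series" means these few. Any claim that something is new, unique, unknown or untested is made for them only; others in the source may bear on it.

Measured compounds:
Compound 1 `CC(C)=CCOc1cccc(Nc2ncccn2)c1` in a functional assay on MT2 cells (Homo sapiens) for cytotoxicity, read by MTT assay; on this read-out lower numbers stand for higher toxicity in this test and higher numbers for lower toxicity in this test: > 100000 nM
Compound 2 `CC(C)=CCOc1cc(Nc2ncccn2)ccc1C`: 78000 nM
Compound 3 `CC(C)=CCOc1cc(Nc2nccc(N)n2)ccc1Cl`: 500 nM

The value of compound 1 is a limit of this assay, not a number (the limit of > 100000 nM in this assay, at which 1 of the 3 values shown sits). From compound 1 to compound 2 the change is methyl in place of hydrogen on an aromatic carbon and the step is an at least 1.2-fold lower number from compound 1 to compound 2 (0.10 log units; that floor lies within the scatter). Compound 3 and compound 1 differ in more than one place; the difference between the two cores is not broken down here. Compound 3 gives the lowest of the two numbers, compound 2 being nearest, and that gap lies beyond the scatter.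

Compound 4 `CC(C)=CCOc1cc(Nc2nc(C)cc(N)n2)ccc1Cl` differs from compound 3 by methyl in place of hydrogen on an aromatic carbon. This is the same kind of change as from compound 1 to compound 2, but it sits on a six-membered aromatic ring with 2 nitrogen, next to the ring nitrogen, meta to a large group and to an amino group, not on a ring of carbon only ortho to the (3-methylbut-2-en-1-yl)oxy group. A small step is expected, a 1.3-fold lower number from compound 3 to compound 4 (0.10 log units; within the scatter), resting on the step of an at least 1.2-fold lower number from compound 1 to compound 2 (0.10 log units; that floor lies within the scatter). For compound 4 in this assay the estimate is 400 nM, expected between 150 nM and 1500 nM.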

Compound 4, half-maximal cytotoxic concentration: < 4 nM
Compound 4 ended at the assay's limit (the forecaster's own chance of this, stated with the estimate: 5%); middle value at least 100-fold (2.00 log units) away from the limit.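

In this assay, methyl in place of hydrogen on an aromatic carbon gives an at least 120-fold lower number from compound 3 to compound 4 (2.09 log units; beyond the scatter), a large step on the core of compound 3. Set beside the earlier step, the two cannot be ranked: the same change on two cores in this assay, an at least 1.2-fold lower number (0.10 log units; that floor lies within the scatter) from compound 1 to compound 2 and an at least 120-fold lower number (2.09 log units; beyond the scatter) from compound 3 to compound 4; the limit leaves it open whether they differ. This shows that the floor seen on the core of compound 1 gave no guide to the step on the core of compound 3, but it gives no rule for carrying the change between cores, and the full size of the new step stays unknown: the limit of < 4 nM in this assay, at which 1 of the 4 values shown sits.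

The compounds shown leave open whether the large step needs the amino group on the six-membered aromatic ring with 2 nitrogen. They also leave open whether ethyl, a longer chain, in place of methyl at that place gives a similar number.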